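A few compounds are considered here, and "the series" means these few. Any claim that something is new, unique, unknown or untested is made for them only; others in the source may bear on it.

Measured in an ADME assay on L6 cells (Rattus norvegicus) for cytotoxicity; on this read-out lower numbers stand for stronger inhibition and higher numbers for weaker inhibition

- Compound 1 `O=C1C=C(c2ccc(C(=O)N3CCCCC3)cc2)C(=O)c2ccccc21` gives 9710 nM
- Compound 2 `O=C1C=C(c2ccco2)C(=O)c2ccccc21` gives 7440 nM
- Compound 3 `O=C1C=C(c2ccc(F)nc2)C(=O)c2ccccc21` gives 2100 nM

Of these three, compound 3 has the lowest number, and its gaps to both compound 2 and compound 1 lie beyond the scatter. Compound 4 `O=C1C=C(c2ccc(Cl)nc2)C(=O)c2ccccc21` has chloro in place of fluoro on an aromatic carbon, next to the ring nitrogen and para to a large group, as counted in chloro in place of fluoro on an aromatic carbon. For the measured compounds named here, no measured pair isolates a single change, so the data give no direct guide to this exchange. In this assay no step beyond the scatter is expected, and the estimated change is a 1.2-fold higher number from compound 3 to compound 4 (0.08 log units; within the scatter). For compound 4 the estimated value is 2500 nM, with an expected range from 900 nM to 7000 nM.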

Compound 4, half-maximal inhibitory concentration: 32400 nM
Estimate against measurement, compound 4: 13-fold (1.11 log units) below; measured number outside the range, above it.
By their numbers in this assay, from the lowest: compound 3; then compounds 2 and 1 (each within the scatter of the next); then compound 4.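

In this assay, for the compounds shown here, chloro in place of fluoro on an aromatic carbon, next to the ring nitrogen and para to a large group, gives a large change, a 15-fold higher number from compound 3 to compound 4 (1.19 log units; beyond the scatter), the first step here that isolates one place. At this position the two halogens are therefore not interchangeable on this read-out, although the change swaps only one heavy atom for another and alters no counted donor, acceptor or net charge. Nothing measured here accounts for the difference. The compounds shown leave open how bromo, an amine or a nitrile would read at this place, and whether hydrogen there would lie nearer compound 3 or compound 4.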